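Trading 2-iodobenzyl for 4-fluorobenzyl on a shared core

The compounds below may be only part of what the source reports. "The series", "measured", "known", "first", "only" and "open" are said of these compounds alone.

Measured in a physicochemical assay for lipophilicity; on this read-out lower numbers stand for lower lipophilicity and higher numbers for higher lipophilicity:
Compound 1 `N#Cc1ccc(OCC2CCN(CCCF)CC2)cc1`: 2.93
Compound 2 `N#Cc1ccc(OCC2CCN(Cc3ccccc3I)CC2)cc1`: 4.3

Of the two measured compounds, compound 2 stands highest, at 4.3 on this scale. The next structure, compound 3 `N#Cc1ccc(OCC2CCN(Cc3ccc(F)cc3)CC2)cc1`, has not yet been measured. It departs from compound 2 by one change: 4-fluorophenyl in place of 2-iodophenyl on a saturated chain carbon bound to an amine nitrogen in a ring.

Among the measured compounds shown here, only one measured step bears on this, and it falls at the same place: a number 1.37 log units higher from compound 1 to compound 2 (beyond the scatter), a large step beyond the scatter. That step brought in the 2-iodophenyl that now leaves, but the new change keeps a six-membered aromatic ring of carbon only, so it is no full return. A single step is thin evidence, yet a partial way back seems the fair reading. In this assay the expected move is downward and beyond the scatter, smaller than the measured step: a number 0.80 log units lower from compound 2 to compound 3 (beyond the scatter) is the estimate. For compound 3 the expected value is 3.5 (estimated range 3.1 to 3.9).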

Compound 3, partition coefficient: 3.22
For compound 3 the middle estimate is 0.28 log units above the measured one; the measured number falls inside the stated range.
By their numbers in this assay, from the lowest: compounds 1 and 3 (each within the scatter of the next); then compound 2.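

In this assay, 4-fluorophenyl in place of 2-iodophenyl on a saturated chain carbon bound to an amine nitrogen in a ring gives a number 1.08 log units lower from compound 2 to compound 3 (beyond the scatter) even though both groups have 7 heavy atoms and one six-membered aromatic ring of carbon only, so a large move at this place does not require a change in either of those counts. Against 2-fluoroethyl at the same place, 4-fluorophenyl gives a number 0.29 log units higher from compound 1 to compound 3 (within the scatter) and so does not separate from it on this read-out, which means that of the three groups only 2-iodophenyl stands apart, and carrying an aromatic ring at this place is not enough to produce the large step seen with compound 2. No evidence at hand bears on the cause of either step.

The compounds shown leave open whether the large step follows the halogen or its place on the ring, since iodine and fluorine differ here along with the numbers in the group names; 4-iodophenyl and 2-fluorophenyl would pull these two apart. Also open, going by these compounds, is how an unsubstituted phenyl, or a phenyl carrying a carboxylic acid or an amine, would read at this place.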